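Naphthyloxyacetyl hydrazones: cytotoxicity on HEL cells

The source may hold more compounds than are shown below. What is called first, only, known or untested is meant among the compounds shown, and "the series" means these compounds.

Measured so far:
compound 1 `O=C(COc1cccc2ccccc12)N/N=C/c1c(O)ccc2ccccc12` — 4 ug/mL
compound 2 `O=C(COc1cccc2ccccc12)N/N=C/c1ccccc1Cl` — 100 ug/mL
compound 3 `O=C(COc1cccc2ccccc12)N/N=C/C=C/c1ccccc1` — 100 ug/mL

In an ADME assay on HEL cells (Homo sapiens) for cytotoxicity (on this read-out lower numbers stand for higher toxicity in this test and higher numbers for lower toxicity in this test), compound 3 stands level with compound 2, the two sharing the highest number of the three. Compound 1 gives a far lower number, well beyond the scatter. Among the measured compounds shown here, the one step that changes the aryl group on the carbon with a double bond to nitrogen, no change at the digits printed from compound 2 to compound 3 (within the scatter), lies within the scatter.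

Compound 4 `CSc1ccc(/C=N/NC(=O)COc2cccc3ccccc23)cc1` differs from compound 3 in that (4-(methylsulfanyl)phenyl in place of 2-phenylethenyl on a carbon with a double bond to nitrogen). For the measured compounds named here, only the step from compound 2 to compound 3 bears on it, and it was flat; nothing measured addresses a methylsulfanyl group. The step of no change at the digits printed from compound 3 to compound 4 (within the scatter) is therefore expected to stay within the scatter. Compound 4 is estimated at 100 ug/mL, between 40 ug/mL and 100 ug/mL.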

Compound 4, minimum cytotoxic concentration: >= 100 ug/mL
Compound 4: only a limit was reported; the forecaster's own chance of this, stated with the estimate: 35%; the middle value lies on the limit itself.
By their numbers in this assay, from the lowest: compound 1; then compounds 2 and 3 (each within the scatter of the next).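

In this assay compound 4 gives >= 100 ug/mL, a limit of the assay and not a number. Neither the step of a number no lower from compound 3 to compound 4 (the limit leaves the size open) nor the step of a number no lower from compound 2 to compound 4 (the limit leaves the size open) can be read in size. What is new at this carbon with a double bond to nitrogen is that a group carrying sulfur, 4-(methylsulfanyl)phenyl, also gives no lower number than the groups before it.

Open, going by these compounds, is how an amine or a carboxylic acid on the phenyl ring would read in this assay. Also open, on these data alone, is whether a hydroxyl group on a simple phenyl ring would bring the number down toward compound 1 at 4 ug/mL.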